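A few compounds are considered here, and "the series" means these few. Any claim that something is new, unique, unknown or untested is made for them only; others in the source may bear on it.

Of the compounds shown here, three with a shared core have been measured in a functional assay on HT-29 cells (Homo sapiens) for inhibition, read by MTT assay, with a stated time of 72 h; a higher number here means a weaker inhibitor, a lower number a stronger inhibitor: compound 1 (`C=C(Br)C(=O)Nc1cccc(/C=C/C(=O)Nc2ccc(F)cc2)c1`) gives 36600 nM, compound 2 (`C=C(Br)C(=O)Nc1cccc(/C=C/C(=O)Nc2cccc(F)c2)c1`) gives 4600 nM, and compound 3 (`C=C(Br)C(=O)Nc1cccc(/C=C/C(=O)Nc2ccc(F)c(F)c2)c1`) gives 8700 nM. Two steps fix the standing of compound 3. The first is a 4.2-fold lower number from compound 1 to compound 3 (0.62 log units; beyond the scatter), which is beyond the scatter. The second is a 1.9-fold higher number from compound 2 to compound 3 (0.28 log units; within the scatter), which lies within it, so the two values of that pair cannot be ranked.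

The next compound is compound 4 (`C=C(Br)C(=O)Nc1cccc(/C=C/C(=O)Nc2ccc(C)cc2)c1`), and the change leading to it is 4-methylphenyl in place of 3,4-difluorophenyl on an amide-type nitrogen. Among the compounds with values here, no measured compound carries a 4-methylphenyl, so no step shows the effect of this group directly. The closest evidence is an 8.0-fold lower number from compound 1 to compound 2 (0.90 log units; beyond the scatter), together with a 4.2-fold lower number from compound 1 to compound 3 (0.62 log units; beyond the scatter). Both are modest, and they show that changes to this aryl group alone can shift the number beyond the scatter. Compound 4 resembles compound 1, at 36600 nM, in having a single group on this ring at the 4 position of its name. A modest rise from compound 3 is therefore expected, though with wide uncertainty. The expected change is a 2.1-fold higher number from compound 3 to compound 4 (0.32 log units; beyond the scatter). For compound 4 the estimated value is 18000 nM, with an expected range from 6000 nM to 50000 nM.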

Compound 4, half-maximal inhibitory concentration: 1200 nM
Compound 4: middle estimate off by 15-fold (1.18 log units), on the high side, and the stated range ends above it.
By their numbers in this assay, from the lowest: compound 4; then compounds 2 and 3 (each within the scatter of the next); then compound 1.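

In this assay the aryl group on the amide-type nitrogen proves able to move the number down further than any fluorinated member had shown: 4-methylphenyl in place of 3,4-difluorophenyl gives a 7.3-fold lower number from compound 3 to compound 4 (0.86 log units; beyond the scatter) and 4-methylphenyl in place of 3-fluorophenyl gives a 3.8-fold lower number from compound 2 to compound 4 (0.58 log units; beyond the scatter) so compound 4 now has the lowest number of the four, with each of its steps beyond the scatter. Within the data shown here, the widest contrast is methyl in place of fluoro on an aromatic carbon, which gives a 31-fold lower number from compound 1 to compound 4 (1.48 log units; beyond the scatter) and is the only large step, so 4-fluorophenyl and 4-methylphenyl mark its two ends and the identity of the group, rather than a single group at that place as such, sets the number. Nothing in the data explains this gain or the gap between methyl and fluoro.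

The compounds shown leave open whether the gain stays with ethyl, chloro or methoxy in place of the methyl of the 4-methylphenyl, or whether it is specific to methyl alone. They also leave open whether a 3-methylphenyl would keep the gain, since the 3-fluorophenyl of compound 2 was the better of the two singly fluorinated groups and no methyl counterpart to it is shown.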